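The source may hold more compounds than are shown below. What is called first, only, known or untested is meant among the compounds shown, and "the series" means these compounds.

Of the compounds shown here, two built on a shared core have been tested in a functional assay on the whole organism (strain Sprague-Dawley) for inhibition, with Rattus norvegicus as the target, with a stated time of 10 min; on this read-out lower numbers stand for an effect already at smaller amounts and higher numbers for an effect only at larger amounts of compound. Compound 1 `COc1ccccc1-c1ncc(C(=O)O)c(=O)[nH]1` gives 10 mg/kg. Compound 2 `CCOc1ccc(N)cc1-c1ncc(C(=O)O)c(=O)[nH]1` gives 1.2 mg/kg, the lowest of the two numbers; compound 1 stands above it by a gap that lies beyond the usual scatter of repeated measurements of this kind. A third compound, compound 3 `CCOc1ccc(S(=O)(=O)N(CC)CC)cc1-c1ncc(C(=O)O)c(=O)[nH]1`, has not yet been measured in this assay. It differs from compound 2 in one place: diethylsulfamoyl in place of amino on an aromatic carbon. Among the measured compounds shown here, nothing among the measured pair shows what such an exchange does here, so only an expectation can be offered. Compound 3 is expected to give about 3 mg/kg in this assay, within a range from 0.8 mg/kg to 12 mg/kg. The step expected here, a 2.5-fold higher number from compound 2 to compound 3 (0.40 log units; beyond the scatter), would be a moderate move toward larger doses, although an outcome within the scatter of the number for compound 2 would not be surprising.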

Compound 3, dose for 50% inhibition: 40 mg/kg
For compound 3 the middle estimate is 13-fold (1.12 log units) below the measured one; measured number above the stated range.
By their numbers in this assay, from the lowest: compound 2; then compound 1; then compound 3.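

In this assay, putting diethylsulfamoyl in place of amino on the aromatic carbon para to the ethoxy group gives a 33-fold higher number from compound 2 to compound 3 (1.52 log units; beyond the scatter), a large move toward larger doses. Among the compounds shown here, this is the first direct exchange at this position, and it shows that the outcome depends strongly on the group placed there. Nothing in the available data explains the size of this step.

Going by these compounds, it remains open whether the two ethyl chains or the sulfonyl part goes with the loss, and compounds carrying an unsubstituted sulfamoyl, a dimethylsulfamoyl or an acetylamino group at this carbon could help separate these. The contribution of amino itself also stays unresolved, since compound 1 differs from compound 2 in more than one place.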